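From 2,5-difluorophenyl to pyridin-3-yl in a cell toxicity test

The compounds below may be only part of what the source reports. "The series", "measured", "known", "first", "only" and "open" are said of these compounds alone.

Values in a toxicity assay on MT2 cells (Homo sapiens) for cytotoxicity, read by XTT assay, with a stated time of 4 days (a higher number here means that more compound is tolerated, a lower number that less compound is tolerated), follow, each a limit and not a number:
Compound 1 `Cc1nc(C)c([C@H](OC(C)(C)C)C(=O)O)c(N2CCC(C)(C)CC2)c1-c1ccc(OCCc2cc(F)ccc2F)cc1` gives >= 33500 nM as a limit
Compound 2 `Cc1nc(C)c([C@H](OC(C)(C)C)C(=O)O)c(N2CCC(C)(C)CC2)c1-c1ccc(SCCc2ccc(F)cc2)cc1` gives >= 32000 nM as a limit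
Compound 3 `Cc1nc(C)c([C@H](OC(C)(C)C)C(=O)O)c(N2CCC(C)(C)CC2)c1-c1ccc(OC2COCC2c2ccc(F)cc2)cc1` gives >= 32000 nM; >= 32000 nM (2 entries) as a limit

Compound 1 stands at >= 33500 nM in this assay and this is a limit, not a number. Compounds 2 and 3 also give only limits, so the three cannot be ranked against one another. Compound 4 `Cc1nc(C)c([C@H](OC(C)(C)C)C(=O)O)c(N2CCC(C)(C)CC2)c1-c1ccc(OCCc2cccnc2)cc1` differs from compound 1 in one place pyridin-3-yl in place of 2,5-difluorophenyl on a saturated chain carbon, two bonds along the chain from an oxygen on an aromatic ring with pyridin-3-yl in place of 2,5-difluorophenyl on a saturated chain carbon, two bonds along the chain from an oxygen on an aromatic ring. Within the data shown here, the one measured step is a step that the two limits leave unreadable from compound 1 to compound 2 and it offers no size to carry over. With no readable step to go on, no change beyond the usual scatter is expected, and the estimated step is an at least 1.0-fold lower number from compound 1 to compound 4 (0.01 log units; that floor lies within the scatter) in size. For compound 4 the estimated value is 32000 nM with an expected range from 15000 nM to 50000 nM and a report as a limit alone is also expected to be likely.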

Compound 4, half-maximal cytotoxic concentration: >= 25000 nM
Compound 4: no number, only a limit; the forecaster's own chance of this, stated with the estimate: 80%; the middle value is on the limit's open side.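

Compounds 1, 2 and 4 each give only a limit in this assay, and the steps from compound 1 to compound 4 and from compound 2 to compound 4 cannot be read. The compounds shown leave open at what concentration any of them harms these cells, and whether pyridin-3-yl in place of 2,5-difluorophenyl changes that concentration.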